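Swapping Methyl for Isopropyl on an Aromatic Ring

The source may report more compounds than this note shows. Statements on the series, on what has been measured and on what is new or still open speak of the compounds shown alone.

In a functional assay on MDA-MB-231 cells (Homo sapiens) for inhibition, read by CCK-8 assay, with a stated time of 48 h (a lower number here means a stronger inhibitor of growth, a higher number a weaker inhibitor of growth), compound 1 `CN1CCN(c2ccc(Nc3ncc(Cl)c(Nc4ccccc4)n3)nc2)CC1` gives 37400 nM. Compound 2 `CN1CCN(c2ccc(Nc3ncc(Cl)c(NCc4ccco4)n3)nc2)CC1` gives 11000 nM, and compound 3 `Cc1cccc(Nc2nc(Nc3ccc(N4CCN(C)CC4)cn3)ncc2Cl)c1` gives 5270 nM. That is the lowest number of the three, and the nearest comparison is a 2.1-fold lower number from compound 2 to compound 3 (0.32 log units; beyond the scatter).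

The next molecule, compound 4 `CC(C)c1cccc(Nc2nc(Nc3ccc(N4CCN(C)CC4)cn3)ncc2Cl)c1`, changes one group of compound 3: isopropyl in place of methyl on an aromatic carbon. In words, isopropyl stands in place of methyl on an aromatic carbon, turning 3-methylphenyl into 3-isopropylphenyl.

The most relevant evidence is the step that put methyl in place of hydrogen on an aromatic carbon, a 7.1-fold lower number from compound 1 to compound 3 (0.85 log units; beyond the scatter). This modest gain lies beyond the scatter. Among the compounds with values here, no measured compound carries isopropyl, so whether a larger group extends that gain remains open. A smaller move in the same direction therefore seems reasonable, and it may not clear the scatter. The expected change is a 1.5-fold lower number from compound 3 to compound 4 (0.18 log units; within the scatter). For compound 4, the estimated value is 3500 nM, with an expected range of 1300 nM to 10000 nM.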

Compound 4, concentration for 50% growth inhibition: 5590 nM
Compound 4: the middle estimate sits 1.6-fold (0.20 log units) below what was measured; low and high end bracket the measured number.
By their numbers in this assay, from the lowest: compounds 3, 4 and 2 (each within the scatter of the next, the first and the last beyond it); then compound 1.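

At this place on the ring, going from methyl to isopropyl gives a 1.1-fold higher number from compound 3 to compound 4 (0.03 log units; within the scatter) in this assay so the two extra carbons bring no further gain over methyl. Isopropyl still stands well apart from hydrogen, with a 6.7-fold lower number from compound 1 to compound 4 (0.83 log units; beyond the scatter) as the step from the unsubstituted phenyl, whereas a 2.0-fold lower number from compound 2 to compound 4 (0.29 log units; within the scatter) leaves compound 4 within the scatter of the furan-bearing compound, a comparison that compound 3 only just clears. Nothing measured here explains why the larger group changes so little.

Going by these compounds, whether a different kind of group on this ring carbon, such as an amine, a carboxylic acid or a longer chain, would shift the number stays open. So does whether isopropyl would behave the same way on another carbon of the ring.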